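This account rests on a few compounds, and the source may have more. Where it says the series, first, only, none or still open, it means among the compounds named here.

The measured compounds and their values:

Compound 1 `Oc1nc2nonc2nc1Nc1ccc(OCC(F)(F)F)cc1` gives in an assay on mitochondria from L6 cells (Rattus norvegicus) for activation, with a stated time of 90 min (on this read-out higher numbers stand for an effect only at larger amounts of compound and lower numbers for an effect already at smaller amounts), a value of 42300 nM.
Compound 2 `Cc1cc(Nc2nc3nonc3nc2O)ccc1OCC(F)(F)F` gives in this assay a value of 7000 nM.
Compound 3 `Cc1cccc(C)c1Nc1nc2nonc2nc1O` gives in this assay only a limit of the assay, > 100000 nM.

Compound 1 and compound 2 share one core and differ in a single place: methyl in place of hydrogen on an aromatic carbon. This change gave a 6.0-fold lower number from compound 1 to compound 2 (0.78 log units; beyond the scatter). Compound 4 `Cc1cc(C)c(Nc2nc3nonc3nc2O)c(C)c1` is not yet measured and stands to compound 3 as compound 2 stands to compound 1, by the same kind of change: methyl in place of hydrogen on an aromatic carbon. The surroundings are not the same, though: in compound 2 the methyl enters ortho to a 2,2,2-trifluoroethoxy group and meta to a large group, while in compound 4 it enters meta to two methyl groups and para to a large group. How the core of compound 3 differs from the core of compound 1 is not broken down here. Compound 3 sits at the limit of > 100000 nM in this assay, at which 1 of the 3 values shown sits, so the earlier step cannot simply be carried over, since a gain starting from a limit gives no number to start from. For compound 4 a step of about an at least 1.6-fold lower number from compound 3 to compound 4 (0.22 log units; that floor lies within the scatter) is expected, leaning on a 6.0-fold lower number from compound 1 to compound 2 (0.78 log units; beyond the scatter) but with wide uncertainty, and the result may again be only a limit. Compound 4 is estimated at 60000 nM, between 15000 nM and 300000 nM.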

Compound 4, half-maximal effective concentration: 113000 nM
Compound 4: middle estimate off by 1.9-fold (0.27 log units), on the low side; the measured number falls inside the stated range.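

No step can be read from compound 3 to compound 4, because the value of compound 3 is only a limit of the assay and not a number: the limit of > 100000 nM in this assay, at which 1 of the 4 values shown sits.

The compounds shown leave open whether this methyl changes the read-out at all on compound 3, and so whether the change seen between compound 1 and compound 2 carries over.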